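From benzyloxy to pyridin-2-yl: a clearance estimate

A few compounds are considered here, and "the series" means these few. Any claim that something is new, unique, unknown or untested is made for them only; others in the source may bear on it.

Three measured compounds share one core and differ in a single group on an aromatic carbon. In an ADME assay on microsomes (Mus musculus) for metabolic stability (on this read-out lower numbers stand for slow clearance and higher numbers for fast clearance), compound 3 (`CNC(=O)[C@@H]1CCCN1S(=O)(=O)c1ccc(Cl)c(COc2cccc3c(OCc4ccccc4)cc(C)nc23)c1Cl`) gives 1820 mL/min/kg. Compound 2 (`CNC(=O)[C@@H]1CCCN1S(=O)(=O)c1ccc(Cl)c(COc2cccc3c(C(F)(F)F)cc(C)nc23)c1Cl`) gives 1380 mL/min/kg, and a 1.3-fold higher number from compound 2 to compound 3 (0.12 log units; within the scatter) lies within the scatter, so these two cannot be told apart. Compound 1 (`CNC(=O)[C@@H]1CCCN1S(=O)(=O)c1ccc(Cl)c(COc2cccc3c(-n4ccnc4)cc(C)nc23)c1Cl`), carrying 1H-imidazol-1-yl, gives 267 mL/min/kg. Both a 5.2-fold higher number from compound 1 to compound 2 (0.71 log units; beyond the scatter) and a 6.8-fold higher number from compound 1 to compound 3 (0.83 log units; beyond the scatter) are modest but lie beyond the scatter.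

Compound 4 (`CNC(=O)[C@@H]1CCCN1S(=O)(=O)c1ccc(Cl)c(COc2cccc3c(-c4ccccn4)cc(C)nc23)c1Cl`) differs from compound 3 by one change: pyridin-2-yl in place of benzyloxy on an aromatic carbon. For the measured compounds named here, the entering group is an aromatic ring holding nitrogen, and compound 1, at 267 mL/min/kg, is the only measured compound with such a ring in that place. One compound is thin support, so only part of a 6.8-fold higher number from compound 1 to compound 3 (0.83 log units; beyond the scatter) is expected to be recovered. The expected change in this assay is a 2.6-fold lower number from compound 3 to compound 4 (0.41 log units; beyond the scatter). Compound 4 is estimated at 700 mL/min/kg, with an expected range from 280 mL/min/kg to 1600 mL/min/kg.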

Compound 4, clearance: 733 mL/min/kg
Beside the measured number, compound 4's estimate is 1.0-fold (0.02 log units) below it, within the range that was stated.
By their numbers in this assay, from the lowest: compound 1; then compounds 4, 2 and 3 (each within the scatter of the next, the first and the last beyond it).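

A second aromatic ring holding nitrogen now separates from benzyloxy at this position, opposite the ring nitrogen: pyridin-2-yl gives a 2.5-fold lower number from compound 3 to compound 4 (0.39 log units; beyond the scatter) in this assay and so shows that the low number of compound 1 was not a lone result among the groups compared with benzyloxy. Trifluoromethyl, however, cannot be told apart from pyridin-2-yl, since a 1.9-fold lower number from compound 2 to compound 4 (0.27 log units; within the scatter) stays within the scatter and the new group therefore clears only one of the two earlier high compounds. Replacing 1H-imidazol-1-yl with pyridin-2-yl still gives a 2.7-fold higher number from compound 1 to compound 4 (0.44 log units; beyond the scatter) and so shows that a nitrogen in an aromatic ring at this place does not by itself reach the number of compound 1.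

As far as these compounds go, how an amine or a carboxylic acid would read on this aromatic carbon remains open. Nothing available here gives a cause for these steps.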